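Swapping the amide ring: from morpholine to trifluoromethylpiperidine

A few compounds are considered here, and "the series" means these few. Any claim that something is new, unique, unknown or untested is made for them only; others in the source may bear on it.

Going by the values given here, in a functional assay on BXPC-3 cells (Homo sapiens) for inhibition, read by MTT assay, with a stated time of 7 days (on this read-out lower numbers stand for stronger inhibition and higher numbers for weaker inhibition), compound 2 `CCN(CC)S(=O)(=O)c1ccc(S(=O)(=O)N2CCC[C@@H](C(=O)N3CCOCC3)C2)cc1` gives 790 nM, the lower of the two numbers so far. Among the compounds with values here, its only neighbour is compound 1 `CCN(CC)S(=O)(=O)c1ccc(S(=O)(=O)N2CCC[C@@H](C(=O)N3CCC(OC)CC3)C2)cc1`, which gives 1420 nM; the step of a 1.8-fold lower number from compound 1 to compound 2 (0.25 log units; within the scatter) is too small to count as a real difference. Compound 3 `CCN(CC)S(=O)(=O)c1ccc(S(=O)(=O)N2CCC[C@@H](C(=O)N3CCC(C(F)(F)F)CC3)C2)cc1` arises from compound 2 by a further change at the same place: 4-(trifluoromethyl)piperidin-1-yl in place of morpholin-4-yl on a carbonyl carbon. Within the data shown here, the only measured step that bears on this position, from compound 1 to compound 2, stayed inside the scatter, so exchanging one saturated six-membered ring for another on this carbonyl has not yet shifted the number noticeably. On that basis the expected step of a 1.1-fold higher number from compound 2 to compound 3 (0.06 log units; within the scatter) is none beyond the scatter. Compound 3 is therefore estimated at 900 nM in this assay, with a likely range from 300 nM to 3000 nM.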

Compound 3, half-maximal inhibitory concentration: 370 nM
The estimate for compound 3 lay 2.4-fold (0.39 log units) above the measured number, within the range that was stated.
By their numbers in this assay, from the lowest: compound 3; then compounds 2 and 1 (each within the scatter of the next).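

In this assay, going by these compounds alone, this position proves able to move the number: the change of ring on the carbonyl carbon gives a 2.1-fold lower number from compound 2 to compound 3 (0.33 log units; beyond the scatter), the first step here beyond the scatter, although a modest one. Within the data shown here, the group on the saturated ring carbon matters as well, since trifluoromethyl in place of methoxy, with the rest of the molecule unchanged, gives a 3.8-fold lower number from compound 1 to compound 3 (0.58 log units; beyond the scatter), also modest but the largest step so far. No measurement shown here explains either step.

From the compounds shown here alone, it remains open whether the lower number is specific to trifluoromethyl, or whether a methyl group, a single fluorine atom or an unsubstituted piperidin-1-yl ring on the same carbonyl carbon would give a similar value. Nor do these compounds show how an amine or a carboxylic acid at that ring carbon would behave.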